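Varying the substituent on the ring nitrogen of compound 3

The source may report more compounds than this note shows. Statements on the series, on what has been measured and on what is new or still open speak of the compounds shown alone.

Measured compounds in a functional assay on MDA-MB-231 cells (Homo sapiens) for cytotoxicity, read by MTT assay, with a stated time of 48 h; on this read-out lower numbers stand for stronger inhibition and higher numbers for weaker inhibition:
- compound 1, `O=C1C[C@H](OCc2cn(C(=O)c3ccccc3)nn2)[C@H]2CO[C@@H]1O2`: 25900 nM
- compound 2, `O=C1C[C@H](OCc2cn(-c3ccc(Cl)cc3)nn2)[C@H]2CO[C@@H]1O2`: 26100 nM
- compound 3, `O=C1C[C@H](OCc2cn(-c3ccccc3)nn2)[C@H]2CO[C@@H]1O2`: 25200 nM

All three compounds share the same bicyclic core and differ only in the group carried on the aromatic nitrogen of the five-membered aromatic ring with three nitrogens. Compound 3 cannot be told apart from its neighbours: the step of a 1.0-fold lower number from compound 1 to compound 3 (0.01 log units; within the scatter) and the step of a 1.0-fold lower number from compound 2 to compound 3 (0.02 log units; within the scatter) are both within the scatter, as is the step of a 1.0-fold higher number from compound 1 to compound 2 (0.00 log units; within the scatter) between the other two. A benzoyl, a 4-chlorophenyl and a plain phenyl at this position thus all give the same number.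

Compound 4, `C=C(C)Cn1cc(CO[C@H]2CC(=O)[C@@H]3OC[C@H]2O3)nn1`, is not yet measured. It differs from compound 3 by 2-methylprop-2-en-1-yl in place of phenyl on an aromatic nitrogen. Within the data shown here, no measured step swaps an aromatic ring for an open chain at this position, so the change is of a new kind. Still, the three earlier swaps at the same nitrogen, none of them beyond the scatter, suggest the assay is not sensitive to what sits there. The expected step of a 1.0-fold higher number from compound 3 to compound 4 (0.01 log units; within the scatter) is therefore none beyond the scatter. Compound 4 is estimated at 26000 nM in this assay, with a range from 12000 nM to 55000 nM.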

Compound 4, half-maximal inhibitory concentration: 26700 nM
Beside the measured number, compound 4's estimate is 1.0-fold (0.01 log units) below it, within the range that was stated.
By their numbers in this assay, from the lowest: compounds 3, 1, 2 and 4 (each within the scatter of the next).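

In this assay, the step of a 1.1-fold higher number from compound 3 to compound 4 (0.03 log units; within the scatter) is within the scatter, so an open chain with no ring and a double bond outside aromatic rings cannot be told apart from phenyl on this aromatic nitrogen. The comparisons with the other two groups read the same way: the step of a 1.0-fold higher number from compound 2 to compound 4 (0.01 log units; within the scatter) and the step of a 1.0-fold higher number from compound 1 to compound 4 (0.01 log units; within the scatter) are both within the scatter. All the earlier groups at this nitrogen contained a six-membered aromatic ring of carbon only, so compound 4 adds something new: across these four compounds, such a ring is not required for a number of this size, and nothing available explains why this position shows so little response.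

The compounds shown leave open whether a group of another kind on this nitrogen, such as an amine, a carboxylic acid or a longer chain, would also give a number within the scatter of these four. All four also share the same core and the same link to the five-membered aromatic ring, so they cannot show whether a new group at either of those places would alter the number.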